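Terminal hydroxy on the aminodecanol chain: compound 2 to compound 4

A few compounds are considered here, and "the series" means these few. Any claim that something is new, unique, unknown or untested is made for them only; others in the source may bear on it.

Measured so far:
compound 1 `CCCCCCCCCC(O)CNC(C)=O` gives "not active" (no number reported)
compound 2 `CCCCCCCCCC(O)CN` gives 4020 nM
compound 3 `NCC(O)CCCCCCCCC(=O)O` gives "not active" (no number reported)

Within the data shown here, in a functional assay on MDA-MB-231 cells (Homo sapiens) for cytotoxicity, read by MTT assay (on this read-out lower numbers stand for stronger inhibition and higher numbers for weaker inhibition), compound 2 is the only compound that returns a number at all; compound 1 and compound 3 come back without one, so compound 2 stands alone as the sole measured reference point. Compound 4 `NCC(O)CCCCCCCCCO` has not yet been tested in this assay. It differs from compound 2 in one place: hydroxy in place of hydrogen on a saturated chain carbon, ten or more bonds along the chain from an oxygen on a saturated carbon. Among the measured compounds shown here, no step between two measured compounds is available to calibrate such a change. Compound 3 carries a carboxylic acid at that far end of the chain and gives "not active" (no number reported), which hints that the chain end tolerates little, although a hydroxy is a smaller change than an acid. The step from compound 2 to compound 4 in this assay is therefore expected to go toward weaker inhibition and to exceed the usual scatter, roughly a 2.2-fold higher number from compound 2 to compound 4 (0.35 log units; beyond the scatter). Compound 4 is estimated at 9000 nM, with a plausible range from 3000 nM to 30000 nM, and a real chance that only an inactive result is reported.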

Compound 4, half-maximal inhibitory concentration: "not active" (no number reported)
Nothing numeric was reported for compound 4; the estimate stays without a comparison.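

In this assay, among these compounds, compound 4 gives "not active" (no number reported) while compound 2 gives 4020 nM so no step between the two can be read. No measured evidence bears on this result. The compounds shown leave open how large any change from hydrogen to hydroxy at this far end of the chain is.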